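Swapping an arylamine for a cyclic amine on the shared core

The compounds below may be only part of what the source reports. "The series", "measured", "known", "first", "only" and "open" are said of these compounds alone.

Compound 1 `Cc1ccc(Nc2nc(C(F)(F)F)ccc2CNC(=O)C(C)c2ccc(NS(C)(=O)=O)c(F)c2)cc1C` is the reference point of this small set. Within the data shown here, in a functional assay on CHO-K1 cells for antagonist activity at transient receptor potential cation channel subfamily V member 1 (Homo sapiens), read by FLIPR (on this read-out higher numbers stand for weaker inhibition and lower numbers for stronger inhibition), compound 1 gives 39.3 nM, the lowest of the three numbers measured so far. Compound 2 `C[C@H](C(=O)NCc1ccc(C(F)(F)F)nc1N1CC[C@@H](N(C)C)C1)c1ccc(NS(C)(=O)=O)c(F)c1` gives 101 nM and compound 3 `C[C@H](C(=O)NCc1ccc(C(F)(F)F)nc1N1CC[C@H](N(C)C)C1)c1ccc(NS(C)(=O)=O)c(F)c1` gives 103 nM; both of those lie beyond the scatter from compound 1, so compound 1 is the strongest inhibitor of the three. Compounds 2 and 3 are twins in everything but configuration, and the step of a 1.0-fold higher number from compound 2 to compound 3 (0.01 log units; within the scatter) shows that drawing the ring stereocentre the other way changes nothing that can be trusted, a result that rests on (the fact that compounds 2 and 3 differ only in the configuration as drawn).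

Compound 4 `CC(C(=O)NCc1ccc(C(F)(F)F)nc1N1CC=CCC1)c1ccc(NS(C)(=O)=O)c(F)c1` is not yet measured. It differs from compound 1 by a group of 6 heavy atoms (5 carbon, 1 nitrogen; one six-membered non-aromatic ring with 1 hetero atom) in place of a group of 9 heavy atoms (8 carbon, 1 nitrogen; one six-membered aromatic ring of carbon only), on an aromatic carbon. Among the measured compounds shown here, no measured step follows exactly this change, so the expectation rests on compounds 2 and 3, which also carry a non-aromatic ring with one hetero atom in place of the (3,4-dimethylphenyl)amino group and give weaker inhibition than compound 1. Compound 4 is therefore expected to give 110 nM, a step of a 2.8-fold higher number from compound 1 to compound 4 (0.45 log units; beyond the scatter), because compound 2 gives 101 nM with a related change. The range expected is 35 nM to 400 nM.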

Compound 4, inhibition constant: 0.3 nM
Compound 4: the middle estimate sits 370-fold (2.56 log units) above what was measured; the measured number lies below the stated range.
By their numbers in this assay, from the lowest: compound 4; then compound 1; then compounds 2 and 3 (each within the scatter of the next).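

At this position on the shared core, the change to the non-aromatic ring gives a 130-fold lower number from compound 1 to compound 4 (2.12 log units; beyond the scatter). The entering ring has fewer heavy atoms than the (3,4-dimethylphenyl)amino group and 0 hydrogen-bond donors, so neither that group's aromatic ring nor its donor is needed for strong inhibition in this assay. A non-aromatic ring here is not enough by itself, however: compound 2 gives 101 nM and compound 3 gives 103 nM, and each carries a dimethylamino group on its ring.

Going by these compounds, it remains open whether the double bond in the ring of compound 4 matters, which a saturated piperidine ring or a morpholine ring at this position could test. Nothing measured here explains why the step is so large.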